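The source may report more compounds than this note shows. Statements on the series, on what has been measured and on what is new or still open speak of the compounds shown alone.

Within the data shown here, compound 2, `CCCCCCOC(=O)CCC(=O)N1CCN(CCCOc2cc3c(Nc4ccc(F)c(Cl)c4)ncnc3cc2OC)CC1`, is one of two compounds measured in a functional assay on A549 cells (Homo sapiens) for cytotoxicity, read by MTT assay, with a stated time of 24 h, tested at 80 uM; a higher number here means a weaker effect of the compound at the concentration tested, a lower number a stronger effect. Compound 2 gives 42.9%. Among the measured compounds shown here, its only measured neighbour is compound 1, `CCOC(=O)CCC(=O)N1CCN(CCCOc2cc3c(Nc4ccc(F)c(Cl)c4)ncnc3cc2OC)CC1`, and compound 1 gives 35.6%. The two numbers sit within the scatter of each other, so compound 2 stands on a par with compound 1 rather than apart from it.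

Compound 3, `CCCCCCCCCCCCCCCOC(=O)CCC(=O)N1CCN(CCCOc2cc3c(Nc4ccc(F)c(Cl)c4)ncnc3cc2OC)CC1`, is not yet measured. It differs from compound 2 in one place: nonyl in place of hydrogen on a saturated chain carbon, six bonds along the chain from an oxygen next to a carbonyl group. For the measured compounds named here, the one measured step that bears on it is the same kind of change, a growth of the chain on the ester side, and it read a number 7.3 percentage points higher from compound 1 to compound 2 (within the scatter), a step within the scatter. Since that step was small, no step beyond the scatter is expected from compound 2 to compound 3 either, though the chain grows further here and the direction of the earlier step, if any, was upward.

The estimate for compound 3 is therefore 48%, with a range from 30% to 68%, corresponding to an expected step of a number 5.1 percentage points higher from compound 2 to compound 3 (within the scatter).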

Compound 3, a percentage reported as activity, at one concentration (the size of the read-out at that concentration, not a potency): 81.1%
Estimate against measurement, compound 3: 33.1 percentage points below; measured number outside the range, above it.
By their numbers in this assay, from the lowest: compounds 1 and 2 (each within the scatter of the next); then compound 3.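

In this assay, the ester end of the molecule proves sensitive to chain length: nonyl in place of hydrogen on a saturated chain carbon, six bonds along the chain from an oxygen next to a carbonyl group, gives a step well outside the scatter (a number 38.2 percentage points higher from compound 2 to compound 3 (beyond the scatter)), which means a clearly weaker effect at the concentration tested. The earlier growth of this chain, butyl in place of hydrogen, gave no step that could be told from the scatter (a number 7.3 percentage points higher from compound 1 to compound 2 (within the scatter)), so the two listed extensions differ in outcome, and a small first step did not predict the larger second one. Nothing shown here accounts for this difference.

The compounds shown leave open whether the number climbs gradually or jumps at one chain length between those of compound 2 and compound 3, a question that an octyl or a decyl ester would address. They also leave open whether a long chain ending in a carboxylic acid or an amine would read like compound 3.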